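This account rests on a few compounds, and the source may have more. Where it says the series, first, only, none or still open, it means among the compounds named here.

Working notes on the series, read in a functional assay on HepG2 cells (Homo sapiens) for inhibition, read by MTT assay, with a stated time of 48 h; on this read-out lower numbers stand for stronger inhibition and higher numbers for weaker inhibition. Compound 1 (`CCOC(=O)C1=C(N/C=N/c2cccnc2Cl)Nc2[nH]nc(C)c2C1c1ccc(N(C)C)cc1`) gives 4890 nM, compound 2 (`CCOC(=O)C1=C(N/N=C(/C(=O)Br)c2ccc(Br)cc2)Nc2[nH]nc(C)c2C1c1ccc(N(C)C)cc1`) gives 65000 nM, and compound 3 (`CCOC(=O)C1=C(N/N=C(/Cl)c2ccc([N+](=O)[O-])cc2)Nc2[nH]nc(C)c2C1c1ccc(N(C)C)cc1`) gives 55500 nM. The number for compound 3 is not separated from its nearest neighbour, as a 1.2-fold lower number from compound 2 to compound 3 (0.07 log units; within the scatter) stays within the scatter. The gap to the lowest number is large, at an 11-fold higher number from compound 1 to compound 3 (1.05 log units; beyond the scatter), and a 13-fold higher number from compound 1 to compound 2 (1.12 log units; beyond the scatter) is of similar size.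

Next is compound 4 (`CCOC(=O)C1=C(N/N=C(/Cl)C#N)Nc2[nH]nc(C)c2C1c1ccc(N(C)C)cc1`), with cyano in place of 4-nitrophenyl on a carbon with a double bond to nitrogen. Going by the values given here, no measured step isolates this change. The closest guide is a 1.2-fold lower number from compound 2 to compound 3 (0.07 log units; within the scatter), which shows no change beyond the scatter between two groups that both keep a six-membered aromatic ring of carbon only. Compound 4 loses that ring, so that step offers only limited support. The large steps from compound 1 show that the group on the amine nitrogen can shift the number in this assay, but they involve a different group. A small move towards a lower number is expected, at about the edge of the scatter. The estimated step is a 2.0-fold lower number from compound 3 to compound 4 (0.30 log units; within the scatter). The estimate for compound 4 is 28000 nM, with an expected range from 8000 nM to 90000 nM.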

Compound 4, half-maximal inhibitory concentration: 23600 nM
Beside the measured number, compound 4's estimate is 1.2-fold (0.07 log units) above it; measured number inside the range.
By their numbers in this assay, from the lowest: compound 1; then compound 4; then compounds 3 and 2 (each within the scatter of the next).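

In this assay, cyano in place of 4-nitrophenyl on a carbon with a double bond to nitrogen gives a modest step that clears the scatter (a 2.4-fold lower number from compound 3 to compound 4 (0.37 log units; beyond the scatter)), whereas compounds 2 and 3, which both keep a six-membered aromatic ring of carbon only, could not be told apart. Loss of that ring therefore does not raise the number here, and the group without a ring also stands apart from the bromine-bearing group of compound 2 (a 2.8-fold lower number from compound 2 to compound 4 (0.44 log units; beyond the scatter)). The group without a ring still does not reach the level of compound 1 (a 4.8-fold higher number from compound 1 to compound 4 (0.68 log units; beyond the scatter)), so the group of compound 1 keeps the lowest number of the four.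

Nothing at hand bears on the reason for these shifts.

On these data alone, whether an amine or a carboxylic acid in place of cyano on this carbon would move the number further remains open.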